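Replacing hydroxy with dimethylamino on a cytotoxicity scaffold

A few compounds are considered here, and "the series" means these few. Any claim that something is new, unique, unknown or untested is made for them only; others in the source may bear on it.

Of the compounds shown here, two sharing one core have been measured. Compound 1 `O=C1/C(=C/c2ccc(Cl)cc2Cl)c2ccccc2N1c1c(Cl)cccc1Cl` gives 2 ug/mL in a functional assay on SW-620 cells (Homo sapiens) for cytotoxicity, read by MTT assay, with a stated time of 3 days; a higher number here means that more compound is needed for the effect, a lower number that less compound is needed. Going by the values given here, compound 2 `O=C1/C(=C/c2ccc(O)cc2)c2ccccc2N1c1c(Cl)cccc1Cl` gives 50 ug/mL in this assay, the higher of the two numbers, and its only neighbour is compound 1, which lies a 25-fold higher number from compound 1 to compound 2 (1.40 log units; beyond the scatter) away in the other direction. That single step swapped the whole aromatic ring attached to the double-bonded chain carbon, and it was large.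

Compound 3 `CN(C)c1ccc(/C=C2/C(=O)N(c3c(Cl)cccc3Cl)c3ccccc32)cc1` differs from compound 2 by one change: dimethylamino in place of hydroxy on an aromatic carbon. Among the compounds with values here, no measured pair shows what hydroxy against dimethylamino does on this core, so the only guidance is indirect: the step from compound 1 to compound 2 shows that altering the group on that ring can move the number far, but it does not say which way this particular exchange will go.

On that basis a moderate move is expected rather than none, with a lower number thought somewhat more likely, so for compound 3 the estimated step is a 3.3-fold lower number from compound 2 to compound 3 (0.52 log units; beyond the scatter). Compound 3 is therefore expected to give about 15 ug/mL in this assay, within a range from 3 ug/mL to 60 ug/mL.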

Compound 3, concentration for half-maximal effect: > 100 ug/mL
Compound 3: only a limit was reported; the forecaster's own chance of this, stated with the estimate: 10%; middle value at least 6.6-fold (0.82 log units) from the limit.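

Compound 3 has no exact reading in this assay, only a limit: the limit of > 100 ug/mL in this assay, at which 1 of the 3 values shown sits. On this core, dimethylamino in place of hydroxy on the aromatic carbon gives an at least 2.0-fold higher number from compound 2 to compound 3 (0.30 log units; that floor lies within the scatter), so the exchange brings no gain, though that floor alone cannot show that the two compounds truly differ. Set against the 2,4-dichlorophenyl group of compound 1, the 4-(dimethylamino)phenyl group gives an at least 50-fold higher number from compound 1 to compound 3 (1.69 log units; beyond the scatter), which means that among the three compounds the low number belongs to compound 1 alone, while the 4-hydroxyphenyl and 4-(dimethylamino)phenyl groups both stand far from it.

The three compounds leave open how far compound 3 really lies from compound 2, and so whether hydroxy and dimethylamino differ at all in this assay. They also leave open whether the low number of compound 1 needs both chlorines on that ring or would hold with a single chlorine, and how a methoxy group, a primary amine or a carboxylic acid would behave on the same aromatic carbon.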